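The compounds below may be only part of what the source reports. "The series", "measured", "known", "first", "only" and "open" are said of these compounds alone.

Measured in a functional assay on SK-MEL-5 cells (Homo sapiens) for inhibition, read by sulforhodamine B assay, with a stated time of 48 h; on this read-out lower numbers stand for stronger inhibition of growth and higher numbers for weaker inhibition of growth:
Compound 1, `COc1ccc2[nH]c(-c3ccccc3)c(C=C(C#N)C#N)c2c1`: 2900 nM
Compound 2, `CC(=O)/C(=C\c1c(-c2ccccc2)[nH]c2ccccc12)S(=O)(=O)c1ccccc1`: 832 nM

Of these two numbers, compound 2 has the lower one; compound 1 sits clearly higher, and that gap lies beyond the usual scatter. Compound 3, `O=C(/C(=C\c1c(-c2ccccc2)[nH]c2ccccc12)S(=O)(=O)c1ccccc1)c1ccccc1`, has not yet been measured. It differs from compound 2 in one place: phenyl in place of methyl on a carbonyl carbon. Going by the values given here, no measured pair shows this particular change, so its size cannot be read from anything here. A step of modest size, in either direction or none beyond the scatter, is expected; the estimated step is a 1.0-fold lower number from compound 2 to compound 3 (0.02 log units; within the scatter). In this assay compound 3 is expected to give 800 nM, within 300 nM to 2500 nM.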

Compound 3, concentration for 50% growth inhibition: 9000 nM
Estimate against measurement, compound 3: 11-fold (1.05 log units) below; the whole stated range lies below it.
By their numbers in this assay, from the lowest: compound 2; then compound 1; then compound 3.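

In this assay the group on this carbonyl carbon matters a great deal: phenyl in place of methyl gives an 11-fold higher number from compound 2 to compound 3 (1.03 log units; beyond the scatter) and so marks a large change, which the first two compounds, differing in more than one place, could not reveal. Acetyl here goes with stronger inhibition of growth than benzoyl. Nothing available accounts for this step.

Still open, as far as these compounds go, is where between methyl and phenyl the change sets in, as an ethyl group or a longer chain might show. Whether an amine on this carbonyl carbon would keep the number of compound 2 is equally unknown.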